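Side-chain variation on the shared core: oral tail flick

The compounds below may be only part of what the source reports. "The series", "measured", "known", "first", "only" and "open" are said of these compounds alone.

Three compounds of the series carry the same core and differ only in the side chain on the saturated chain carbon two bonds from the amide-type nitrogen and the carbonyl carbon. In a functional assay on the whole organism (Tail, strain ICR) with Mus musculus as the target, in the tail flick test, with a stated time of 90 min, at a dose of 25 umol/kg by the oral route (on this read-out lower numbers stand for a weaker effect and higher numbers for a stronger effect at the one dose given), compound 1 `CSCC[C@H](NC(=O)CN(c1nc(Cl)nc2[nH]cnc12)C1CC1)C(=O)OCc1ccccc1` gives 44.6%, compound 2 `O=C(O)CC[C@H](NC(=O)CN(c1nc(Cl)nc2[nH]cnc12)C1CC1)C(=O)O` gives 44.7%, and compound 3 `O=C(O)C[C@H](NC(=O)CN(c1nc(Cl)nc2[nH]cnc12)C1CC1)C(=O)O` gives 25.1%. Compound 3 stands lowest of the three; its nearest neighbour is compound 1 and its furthest is compound 2, both beyond the scatter. Among the measured compounds shown here, the one measured step in this assay is a number 19.6 percentage points lower from compound 2 to compound 3 (beyond the scatter).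

Compound 4 `CSCC[C@H](NC(=O)CN(c1nc(Cl)nc2[nH]cnc12)C1CC1)C(=O)O` is not yet measured. It differs from compound 3 by (methylsulfanyl)methyl in place of carboxy on a saturated chain carbon, two bonds along the chain from an amide-type nitrogen and a carbonyl carbon. For the measured compounds named here, no measured step covers this exact exchange. The step that bears on it is the shortening from compound 2 to compound 3, which lowered this assay by a modest amount; compound 4 undoes the carboxy at that position and installs the chain found in compound 1, whose value in this assay is close to that of compound 2. A step upward beyond the scatter is therefore expected, estimated as a number 17.9 percentage points higher from compound 3 to compound 4 (beyond the scatter). Compound 4 is expected to give about 43%, in the range 27% to 60%.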

Compound 4, a percentage reported as activity, at one dose (the size of the read-out at that dose, not a potency): 14%
Compound 4: the middle estimate sits 29 percentage points above what was measured; the whole stated range lies above it.
By their numbers in this assay, from the lowest: compound 4; then compound 3; then compounds 1 and 2 (each within the scatter of the next).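

In this assay, (methylsulfanyl)methyl in place of carboxy on the saturated chain carbon, two bonds along the chain from an amide-type nitrogen and a carbonyl carbon, gives a number 11.1 percentage points lower from compound 3 to compound 4 (beyond the scatter) and so shows that this side chain does not carry the read-out of compound 1 on its own. The ester matters with this side chain: hydrogen in place of benzyl on an oxygen next to a carbonyl group gives a number 30.6 percentage points lower from compound 1 to compound 4 (beyond the scatter) and is a large step in this assay. With the free acid present in both compounds, methylsulfanyl in place of carboxy, three bonds along the chain from the same two atoms, gives a number 30.7 percentage points lower from compound 2 to compound 4 (beyond the scatter) and separates the side chains of compound 2 and compound 4 widely.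

Still open, from the compounds shown here alone, are whether a benzyl group on the corresponding oxygen of compound 2 or compound 3 changes the read-out as it does here, and how an amine or a longer carboxylic acid chain at this position reads. Nothing at hand gives a reason for these steps.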